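The source may report more compounds than this note shows. Statements on the series, on what has been measured and on what is new or still open speak of the compounds shown alone.

Measured in a physicochemical assay for lipophilicity; on this read-out higher numbers stand for higher lipophilicity and lower numbers for lower lipophilicity:
compound 1 `CC(C)c1cc(Br)cc(C(C)C)c1O` gives 5.49;
compound 2 `CC(C)c1cc([N+](=O)[O-])cc(C(C)C)c1O` gives 4.71;
compound 3 `CC(C)c1cc(N(C)C)cc(C(C)C)c1O` gives 4.52.

Compound 1 stands highest of the three. Swapping its bromo for nitro gave a number 0.78 log units lower from compound 1 to compound 2 (beyond the scatter), and swapping it for dimethylamino gave a number 0.97 log units lower from compound 1 to compound 3 (beyond the scatter); those two products sit close together, a number 0.19 log units lower from compound 2 to compound 3 (within the scatter). Compound 4 `CC(C)c1cc(NS(C)(=O)=O)cc(C(C)C)c1O` takes the same kind of step from compound 1: methanesulfonamido in place of bromo on an aromatic carbon. Both earlier replacements of bromo on this carbon lowered the reading by a modest amount, so a drop is expected here as well; the entering group is larger than bromo and, unlike it, brings hydrogen-bond donor and acceptor atoms, so the fall is estimated to exceed both earlier ones, a number 1.89 log units lower from compound 1 to compound 4 (beyond the scatter). For compound 4 the expected value in this assay is 3.6, within 3.1 to 4.1.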

Compound 4, partition coefficient: 3.14
Compound 4: middle estimate off by 0.46 log units, on the high side; the measured number falls inside the stated range.
By their numbers in this assay, from the lowest: compound 4; then compounds 3 and 2 (each within the scatter of the next); then compound 1.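

In this assay this aromatic carbon proves able to carry a much larger fall than the nitro and dimethylamino replacements revealed: methanesulfonamido gives a number 2.35 log units lower from compound 1 to compound 4 (beyond the scatter). Unlike those two replacements, which sit within the scatter of each other, the new group stands clearly apart from both, with a number 1.38 log units lower from compound 3 to compound 4 (beyond the scatter) and a number 1.57 log units lower from compound 2 to compound 4 (beyond the scatter). Nothing available accounts for the size of this fall.

As far as these compounds go, it remains open whether a primary amine or a carboxylic acid on this carbon would read as low as compound 4, and whether a longer chain in place of the methyl on the sulfonyl group would shift the reading.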